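This account rests on a few compounds, and the source may have more. Where it says the series, first, only, none or still open, it means among the compounds named here.

In an assay on isolated protein for inhibition of ubiquitin carboxyl-terminal hydrolase 7 (Homo sapiens), with stated times of 30 min and 2 h (a higher number here means a weaker inhibitor, a lower number a stronger inhibitor), compound 3 `Cc1ccc(-c2ccc(CN3CCC(O)(Cn4cnc5c(-c6ccc(CN)cc6)n(C)nc5c4=O)CC3)c(Cl)c2)s1` gives 101 nM, the second highest of the three numbers. Compound 1 `Cn1nc2c(=O)n(CC3(O)CCN(Cc4ccc(-c5ccco5)cc4Cl)CC3)cnc2c1-c1ccc(OC(F)F)cc1` gives 179 nM, within the scatter of compound 3, while compound 2 `Cn1nc2c(=O)n(CC3(O)CCN(Cc4ccc(-c5cccs5)cc4Cl)CC3)cnc2c1-c1ccc(CN)cc1` gives 38.6 nM, a lower number beyond the scatter. Within the data shown here, the only single-place step measured is a 2.6-fold higher number from compound 2 to compound 3 (0.42 log units; beyond the scatter). Compound 4 `Cn1nc2c(=O)n(CC3(O)CCN(Cc4ccc(-c5ccco5)cc4Cl)CC3)cnc2c1-c1ccc(CN)cc1` carries furan-2-yl in place of 5-methylthiophen-2-yl on an aromatic carbon. The step from compound 2 to compound 3 bears on this in reverse, since the methyl is lost; the change of the five-membered ring itself has no single-place comparison, and compounds 1 and 2 differ in two places. A step of about a 2.0-fold lower number from compound 3 to compound 4 (0.31 log units; beyond the scatter) is therefore expected, toward a lower number. The estimate for compound 4 in this assay is 50 nM, with a range of 20 nM to 130 nM.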

Compound 4, half-maximal inhibitory concentration: 18.1 nM
Beside the measured number, compound 4's estimate is 2.8-fold (0.44 log units) above it, and the stated range ends above it.
By their numbers in this assay, from the lowest: compound 4; then compound 2; then compounds 3 and 1 (each within the scatter of the next).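

In this assay, the ring on the aromatic carbon para to a large group now has a single-place comparison: furan-2-yl gives a 2.1-fold lower number from compound 2 to compound 4 (0.33 log units; beyond the scatter), and against the methylated ring it gives a 5.6-fold lower number from compound 3 to compound 4 (0.75 log units; beyond the scatter). With furan-2-yl held fixed, aminomethyl in place of difluoromethoxy gives a 9.9-fold lower number from compound 1 to compound 4 (1.00 log units; beyond the scatter). No measurement here accounts for either effect. Still open, from the compounds shown here alone, is how 5-methylfuran-2-yl or phenyl would read at this carbon, and whether a methyl on furan would follow the step of a 2.6-fold higher number from compound 2 to compound 3 (0.42 log units; beyond the scatter).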